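Ethoxy in Place of Methyl: Expected Solubility for Compound 4

The source may hold more compounds than are shown below. What is called first, only, known or untested is meant among the compounds shown, and "the series" means these compounds.

Compound 1 `C[C@]1(COc2ccc(N3CCN(S(=O)(=O)c4ccc(F)cc4)CC3)cc2)Cn2cc([N+](=O)[O-])nc2O1` gives 8.33 ug/mL in a physicochemical assay for solubility, read by HPLC, with a stated time of 4 h, at pH 7; on this read-out lower numbers stand for lower solubility and higher numbers for higher solubility. Compound 2 `Cc1ccc(NC(=O)Nc2ccc(OC[C@@]3(C)Cn4cc([N+](=O)[O-])nc4O3)cc2)cc1` returns only a limit of the assay, < 1 ug/mL. Compound 3 `C[C@]1(COc2ccc(NC(=S)Nc3ccc(OC(F)(F)F)cc3)cc2)Cn2cc([N+](=O)[O-])nc2O1` likewise returns only a limit, < 1 ug/mL.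

Compound 2 stands at the lower edge of what has been measured: its result in this assay is a limit, not a number. the limit of < 1 ug/mL in this assay, at which 2 of the 3 values shown sit, marks where two of the three measured compounds sit, and compound 1 alone returns a number. Among the compounds with values here, no two measured compounds differ in a single place, so no measured step is available to scale from.

Compound 4 `CCOc1ccc(NC(=O)Nc2ccc(OC[C@@]3(C)Cn4cc([N+](=O)[O-])nc4O3)cc2)cc1` differs from compound 2 by ethoxy in place of methyl on an aromatic carbon. With compound 2 at a limit, there is no measured anchor for the size of this change. Compound 3, with a different outer group, also sits at the limit. The step from compound 2 to compound 4 is expected to be small, a number no lower from compound 2 to compound 4 (the limit leaves the size open), in no clear direction and not beyond the scatter. Compound 4 is therefore estimated at 1 ug/mL, within a range of 0.3 ug/mL to 3 ug/mL, and most likely reported again as a limit.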

Compound 4, solubility: 6.66 ug/mL
Beside the measured number, compound 4's estimate is 6.7-fold (0.82 log units) below it; the whole stated range lies below it.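

In this assay, ethoxy in place of methyl on an aromatic carbon, para to a large group, gives an at least 6.6-fold higher number from compound 2 to compound 4 (0.82 log units; beyond the scatter). Within the data shown here, this is the first single-place step in the set, and it shows that a change at this position alone can carry a compound from a limit of the assay to a measured number, something that compound 1, compound 2 and compound 3, which differ from one another in more than one place, could not show. The true size of the step remains unknown, and it can be read only as a lower bound because the result for compound 2 is a limit and not a number: the limit of < 1 ug/mL in this assay, at which 2 of the 4 values shown sit.

The compounds shown leave open whether the step goes with the oxygen of ethoxy or with its carbons, a question that a methoxy group or a propyl chain at the same place would help to separate. They also leave open whether an amine or a carboxylic acid here would give a step of similar size, and whether ethoxy would have a like effect on the outer ring of compound 3.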